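Trading Cyclohexyloxy for an Acetylated Piperidine Amine

The source may report more compounds than this note shows. Statements on the series, on what has been measured and on what is new or still open speak of the compounds shown alone.

For the measured compounds named here, in a functional assay on Shh Light II cells (Mus musculus) for inhibition, read by a luciferase reporter (on this read-out lower numbers stand for stronger inhibition and higher numbers for weaker inhibition), compound 1 `O=C(NC1CCNCC1)N1CCC(c2nc(-c3ccc4ccccc4n3)no2)CC1` gives 2500 nM, while compound 2 `O=C(OC1CCCCC1)N1CCC(c2nc(-c3ccc4ccccc4n3)no2)CC1` gives 580 nM, the lower of the two numbers so far. Compound 3 `CC(=O)N1CCC(NC(=O)N2CCC(c3nc(-c4ccc5ccccc5n4)no3)CC2)CC1` has (1-acetylpiperidin-4-yl)amino in place of cyclohexyloxy on a carbonyl carbon. Going by the values given here, the only measured step that bears on this is modest: a 4.3-fold lower number from compound 1 to compound 2 (0.63 log units; beyond the scatter), with cyclohexyloxy replacing (piperidin-4-yl)amino. Among the compounds with values here, compound 3 returns to that amino group, now carrying an acetyl that no measured compound tests. A modest step toward a higher number is therefore expected in this assay, namely a 2.6-fold higher number from compound 2 to compound 3 (0.41 log units; beyond the scatter). For compound 3 the estimate is 1500 nM, with an expected range of 500 nM to 4500 nM.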

Compound 3, half-maximal inhibitory concentration: 500 nM
For compound 3 the middle estimate is 3.0-fold (0.48 log units) above the measured one; measured number inside the range.
By their numbers in this assay, from the lowest: compounds 3 and 2 (each within the scatter of the next); then compound 1.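

In this assay, acetyl on the ring nitrogen of the piperidine gives a 5.0-fold lower number from compound 1 to compound 3 (0.70 log units; beyond the scatter), so the amino-linked group need not cost activity at this position once that nitrogen is acylated. Exchanging cyclohexyloxy for (1-acetylpiperidin-4-yl)amino on the carbonyl carbon gives a 1.2-fold lower number from compound 2 to compound 3 (0.06 log units; within the scatter), so the two groups cannot be told apart here despite their different atoms. Nothing available explains the effect of the acetyl. On these data alone, whether a propanoyl or methanesulfonyl group on that ring nitrogen would match acetyl stays open. So does how cyclohexylamino on the carbonyl carbon would compare with cyclohexyloxy.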